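A few compounds are considered here, and "the series" means these few. Any claim that something is new, unique, unknown or untested is made for them only; others in the source may bear on it.

Compound 1 `CCO/N=C(\C)CN1CCN(c2nc(=O)c3cc(C(F)(F)F)cc([N+](=O)[O-])c3s2)CC1`: in an ADME assay on Vero cells (Chlorocebus sabaeus) for cytotoxicity (a higher number here means that more compound is tolerated, a lower number that less compound is tolerated), compound 1 gives > 64 ug/mL, which is a limit of the assay and not a number.
Compound 2 `CO/N=C(\C)CCN1CCN(c2nc(=O)c3cc(C(F)(F)F)cc([N+](=O)[O-])c3s2)CC1`: in this assay compound 2 gives > 64 ug/mL, again a limit.
Compound 3 `C/C(CCN1CCN(c2nc(=O)c3cc(C(F)(F)F)cc([N+](=O)[O-])c3s2)CC1)=N\OCc1ccccc1`: in this assay compound 3 gives > 64 ug/mL, again a limit.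

Compound 2 thus stands at the same limit as the other two measured compounds; no number is known for any of them, so none can be ordered against another. The steps between them, a step that the two limits leave unreadable from compound 1 to compound 2, a step that the two limits leave unreadable from compound 1 to compound 3 and a step that the two limits leave unreadable from compound 2 to compound 3, are all unreadable, since (the limit of > 64 ug/mL in this assay, at which 3 of the 3 values shown sit).

Compound 4 `CON=C1CCC(CN2CCN(c3nc(=O)c4cc(C(F)(F)F)cc([N+](=O)[O-])c4s3)CC2)CC1` is the next member, differing from compound 2 as follows: a group of 9 heavy atoms (7 carbon, 1 nitrogen, 1 oxygen; one six-membered non-aromatic ring of carbon only) in place of a group of 6 heavy atoms (4 carbon, 1 nitrogen, 1 oxygen; no ring), on a saturated chain carbon bound to an amine nitrogen in a ring. For the measured compounds named here, the only step that bears on this change is the one from compound 2 to compound 3, and it, like the others, cannot be read because of the limit of > 64 ug/mL in this assay, at which 3 of the 3 values shown sit. With every measured value sitting at the limit, the step from compound 2 to compound 4 is expected to be a step that the limit leaves unreadable from compound 2 to compound 4, that is, no movement beyond the scatter is expected, and most likely another limit.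

In this assay compound 4 is therefore estimated at 80 ug/mL, with a range from 40 ug/mL to 160 ug/mL, and the assay is expected to report only a limit.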

Compound 4, half-maximal cytotoxic concentration: > 64 ug/mL
Compound 4: no number, only a limit (the forecaster's own chance of this, stated with the estimate: 85%); the middle value does not contradict the limit.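

In this assay compound 4 gives > 64 ug/mL, again a limit, so none of the steps linking compound 4 to compound 1, compound 2 or compound 3 can be read: the limit of > 64 ug/mL in this assay, at which 4 of the 4 values shown sit.

The compounds shown leave open where any half-maximal cytotoxic concentration lies and whether these side chains differ at all.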